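Changing the amide side chain of a cyclohexyl benzimidazole series

A few compounds are considered here, and "the series" means these few. Any claim that something is new, unique, unknown or untested is made for them only; others in the source may bear on it.

Three compounds sharing one core have been examined for toxicity toward monkey kidney cells. In an ADME assay on Vero cells (Chlorocebus sabaeus) for cytotoxicity, read by resazurin assay, with a stated time of 3 days (a higher number here means a weaker inhibitor, a lower number a stronger inhibitor), compound 1, `CCCc1ccc(C(=O)Nc2cc3nc(C4CCCCC4)[nH]c3cc2N(C)C)cc1`, gives > 100 ug/mL, which is a limit of the assay rather than a number. Compound 3, `O=C(CCc1ccccc1)Nc1cc2nc(C3CCCCC3)[nH]c2cc1N1CCCC1`, gives > 100 ug/mL in this assay, again a limit. Compound 2, `CCCc1ccc(C(=O)Nc2cc3nc(C4CCCCC4)[nH]c3cc2N(CC)CC)cc1`, carries a diethylamino group in place of the dimethylamino group of compound 1. In this assay compound 2 has no result: "not determined" (no result reported). So compound 2 stands without a number of its own, while the two neighbouring compounds both sit at the limit, which is what the limit of > 100 ug/mL in this assay, at which 2 of the 3 values shown sit, records.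

The unmeasured compound 4, `CCCOCC(=O)Nc1cc2nc(C3CCCCC3)[nH]c2cc1N(CC)CC`, keeps the core and the diethylamino group of compound 2 and alters only the amide side chain: propoxymethyl in place of 4-propylphenyl on a carbonyl carbon. Within the data shown here, since no measured step connects compound 2 to compound 4, the size of any shift in this assay cannot be read from the data; the expectation is simply that compound 4 behaves like compound 1 and compound 3 and shows no step beyond the scatter, staying at the limit.

Compound 4 is therefore expected to give about 100 ug/mL in this assay, within a range of 50 ug/mL to 200 ug/mL.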

Compound 4, half-maximal inhibitory concentration: > 100 ug/mL
Compound 4 was reported as a limit; the forecaster's own chance of this, stated with the estimate: 75%; the middle value lies on the limit itself.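

In this assay compound 4 gives > 100 ug/mL as a limit, not a number. Among these compounds, no step from compound 2 to compound 4 can be read: compound 2 has no number to compare with it. The compounds shown leave open whether exchanging 4-propylphenyl for propoxymethyl changes toxicity toward these cells at all.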